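The compounds below may be only part of what the source reports. "The series", "measured", "known", "first", "only" and "open" are said of these compounds alone.

In a functional assay on the whole organism with Rattus norvegicus as the target (a lower number here means that less compound is needed, a higher number that more compound is needed for the effect), compound 2 `CCNCCNC(=O)c1cc(Cl)c(N)cc1OC` stands at > 30 mg/kg, which is a limit and not a number. Compound 3 `CCN(CCNC(=O)c1cc(Cl)c(N)cc1OC)Cc1ccc(OC)cc1` carries 4-methoxybenzyl in place of hydrogen on an amine nitrogen. Among the measured compounds shown here, the one measured step that bears on this change starts from compound 1 `CCN(CCNC(=O)c1cc(Cl)c(N)cc1OC)Cc1ccoc1`, which gives 3 mg/kg in this assay. That step, an at least 10-fold higher number from compound 1 to compound 2 (1.00 log units; beyond the scatter), removes (furan-3-yl)methyl from the same nitrogen and lies beyond the scatter. Restoring a group there is therefore expected to lower the number, with an estimated change of an at least 6.0-fold lower number from compound 2 to compound 3 (0.77 log units; beyond the scatter). Compound 3 is expected at 5 mg/kg, with an estimated range of 1 mg/kg to 25 mg/kg.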

Compound 3, dose for half-maximal effect: 0.2 mg/kg
The estimate for compound 3 lay 25-fold (1.40 log units) above the measured number; the measured number lies below the stated range.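

On this amine nitrogen, 4-methoxybenzyl gives in this assay an at least 150-fold lower number from compound 2 to compound 3 (2.17 log units; beyond the scatter). Compound 2 stands at > 30 mg/kg, which is a limit and not a number. The identity of the group also counts, not only its presence: 4-methoxyphenyl in place of furan-3-yl on the saturated chain carbon gives a 15-fold lower number from compound 1 to compound 3 (1.18 log units; beyond the scatter). The compounds shown leave open what a plain benzyl group would give on this nitrogen, and so how much of that step belongs to the methoxy group. Also open, as far as these compounds go, is what a 4-chlorobenzyl or a pyridinylmethyl group would give there.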